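Swapping thiophene for pyridine on a low-toxicity compound

The source may hold more compounds than are shown below. What is called first, only, known or untested is meant among the compounds shown, and "the series" means these compounds.

Measured in an ADME assay on Vero cells (Chlorocebus sabaeus) for cytotoxicity, read by MTT assay, with a stated time of 96 h; on this read-out lower numbers stand for higher toxicity in this test and higher numbers for lower toxicity in this test:
- compound 1 `COc1cc(NCc2ccc(C)o2)ccc1-c1cnco1`: 45200 nM
- compound 2 `COc1ccc(-c2cnco2)cc1NCc1ccc(C)s1`: 42700 nM
- compound 3 `COc1cc(/N=C/c2cccs2)ccc1-c1cnco1`: 406000 nM

Among these three, compound 3 stands highest, and its distance to each of the other two lies beyond the scatter. Compound 1 and compound 2 lie within the scatter of each other.

The next compound to be tested is compound 4 `COc1cc(/N=C/c2ccncc2)ccc1-c1cnco1`. It differs from compound 3 by a single change: pyridin-4-yl in place of thiophen-2-yl on a carbon with a double bond to nitrogen. In words, this is pyridin-4-yl in place of thiophen-2-yl on a carbon with a double bond to nitrogen.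

Among the compounds with values here, no two measured compounds differ in one place only, so the data offer no direct guide to the size of this step. Within the data shown here, the expectation rests on compound 3, whose 406000 nM is the highest number so far and leaves more room below than above. A moderate move downward in this assay is therefore expected, near the edge of the scatter. The estimated change is a 2.0-fold lower number from compound 3 to compound 4 (0.31 log units; beyond the scatter). The estimated value for compound 4 is 200000 nM, with an expected range from 70000 nM to 500000 nM.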

Compound 4, half-maximal cytotoxic concentration: 239000 nM
Compound 4: the middle estimate sits 1.2-fold (0.08 log units) below what was measured; low and high end bracket the measured number.
By their numbers in this assay, from the lowest: compounds 2 and 1 (each within the scatter of the next); then compounds 4 and 3 (each within the scatter of the next).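

In this assay, within the data shown here, the first change that can be read in one place, pyridin-4-yl in place of thiophen-2-yl on a carbon with a double bond to nitrogen, gives a 1.7-fold lower number from compound 3 to compound 4 (0.23 log units; within the scatter). At this position, then, one five-membered aromatic ring with a single hetero atom gave way to a six-membered aromatic ring with a single hetero atom, and the two numbers cannot be told apart beyond the usual scatter of this test, so the high number of compound 3 is not tied to the thiophen-2-yl group alone. No measured evidence is available here that would explain this result.

From the compounds shown here alone, what phenyl, pyridin-3-yl or a ring carrying a carboxylic acid would do on this same carbon remains open, so one swap does not yet show how widely the position accepts change. No pair shown isolates the double bond to nitrogen itself, and its share in the numbers therefore stays unknown.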